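The compounds below may be only part of what the source reports. "The series", "measured", "known", "first", "only" and "open" are said of these compounds alone.

Measured so far in an assay on CHO cells for displacement of a labelled ligand from C-X-C chemokine receptor type 1 (Homo sapiens); on this read-out higher numbers stand for weaker inhibition and lower numbers for stronger inhibition:

Compound 1, `CN(C)S(=O)(=O)c1c(Cl)ccc(N/C(=N/C#N)Nc2cccc(Cl)c2F)c1O`, gives 6200 nM.
Compound 2, `Cc1ccc(N/C(=N/C#N)Nc2ccccc2Br)c(O)c1S(=O)(=O)N(C)C`, gives 187 nM.

Of these two, compound 2 stands at the lower number, and the gap to compound 1 lies well beyond the usual scatter, so compound 2 is the stronger inhibitor of the pair. The next compound, compound 3, `CN(C)S(=O)(=O)c1c(C(F)(F)F)ccc(N/C(=N/C#N)Nc2ccccc2Br)c1O`, is not yet measured. It differs from compound 2 by one change: trifluoromethyl in place of methyl on an aromatic carbon. For the measured compounds named here, no measured pair shows the effect of this swap, so the expectation rests on compound 2 alone. A small step is expected, a 1.3-fold higher number from compound 2 to compound 3 (0.13 log units; within the scatter), toward slightly weaker binding or none beyond the scatter. Compound 3 is expected to give about 250 nM, ranging from 80 nM to 800 nM.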

Compound 3, half-maximal inhibitory concentration: 100 nM
For compound 3 the middle estimate is 2.5-fold (0.40 log units) above the measured one; the range from low to high includes it.
By their numbers in this assay, from the lowest: compounds 3 and 2 (each within the scatter of the next); then compound 1.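

On an aromatic carbon ortho to a dimethylsulfamoyl group, trifluoromethyl in place of methyl gives a 1.9-fold lower number from compound 2 to compound 3 (0.27 log units; within the scatter) in this assay, so this read-out does not separate the two groups here. A group of 4 heavy atoms thus takes the place of one of 1 heavy atom at this position without a change beyond the scatter. No measurement shown offers an explanation for this result.

On these data alone, how an amine, a carboxylic acid or a longer chain would behave on this carbon remains open. So does whether the swap would give the same outcome on the core of compound 1.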